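Acetamido added to the sulfonyl ring of compound 3

This account rests on a few compounds, and the source may have more. Where it says the series, first, only, none or still open, it means among the compounds named here.

Compound 3 `O=C1/C(=C/c2cccc(F)c2)CN(S(=O)(=O)c2ccccc2)C/C1=C\c1cccc(F)c1` sits second highest of the three numbers in a functional assay on SMMC-7721 cells (Homo sapiens) for cytotoxicity, read by MTT assay, with a stated time of 24 h (on this read-out higher numbers stand for weaker inhibition and lower numbers for stronger inhibition), where compound 3 gives 12900 nM. Compound 2 `N#Cc1ccc(S(=O)(=O)N2C/C(=C\c3ccccc3F)C(=O)/C(=C/c3ccccc3F)C2)cc1` gives 14600 nM, within the scatter of compound 3, while compound 1 `O=C1/C(=C/c2ccccc2F)CN(S(=O)(=O)c2ccc(C(F)(F)F)cc2)C/C1=C\c1ccccc1F` gives 5200 nM, a clearly lower number. Compound 4 `CC(=O)Nc1ccc(S(=O)(=O)N2C/C(=C\c3cccc(F)c3)C(=O)/C(=C/c3cccc(F)c3)C2)cc1` differs from compound 3 by acetamido in place of hydrogen on an aromatic carbon. Among the measured compounds shown here, the only step at the same position, a 2.8-fold higher number from compound 1 to compound 2 (0.45 log units; beyond the scatter), swaps one group for another on a core with a different fluorine placement, so it does not speak directly to adding a group where hydrogen stood; it shows that changing this position can move the number modestly. For compound 4 the expected step is a 1.2-fold higher number from compound 3 to compound 4 (0.07 log units; within the scatter), with an estimate of 15000 nM and a range from 6000 nM to 38000 nM.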

Compound 4, half-maximal inhibitory concentration: 10300 nM
Estimate against measurement, compound 4: 1.5-fold (0.16 log units) above, and the stated range covers the measured number.
By their numbers in this assay, from the lowest: compounds 1, 4, 3 and 2 (each within the scatter of the next, the first and the last beyond it).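

Placing acetamido on the sulfonyl ring gives a 1.3-fold lower number from compound 3 to compound 4 (0.10 log units; within the scatter) in this assay. Among the compounds shown here, this is the first view of a group added where hydrogen stood, rather than one group swapped for another. On the core of compound 3, going from phenyl to 4-acetamidophenyl does not move the number beyond the scatter, and nothing measured here offers an explanation. Still open, as far as these compounds go, is whether an amine or a carboxylic acid at this same place would also leave the number within the scatter, or would shift it clearly.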